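The source may hold more compounds than are shown below. What is called first, only, known or untested is meant among the compounds shown, and "the series" means these compounds.

Measured so far in a functional assay on HeLa cells (Homo sapiens) for cytotoxicity, read by MTT assay; a lower number here means a stronger inhibitor, a higher number a weaker inhibitor:

compound 1 `COC(C)CO[C@H](CC=C(C)C)C1=CC(=O)c2c(O)ccc(O)c2C1=O` — 53400 nM
compound 2 `CC(C)=CC[C@@H](OC(=O)CC(O)c1ccccc1)C1=CC(=O)c2c(O)ccc(O)c2C1=O` — 44500 nM

Of the compounds shown here, two have been measured, and both return numbers in the same region. Compound 2 carries the lower of the two values, with 44500 nM in this assay, but its gap to compound 1 lies within the usual scatter of repeated measurements, so the two values cannot be told apart and neither compound can be called the stronger of the pair.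

Compound 3 `CCCCC(C)(O)CC(=O)O[C@H](CC=C(C)C)C1=CC(=O)c2c(O)ccc(O)c2C1=O` is the next member and has not yet been measured. Relative to compound 2 the change is confined to the ester side chain:

1-hydroxy-1-methylpentyl in place of hydroxy(phenyl)methyl on a saturated chain carbon bound to a carbonyl carbon

Among the compounds with values here, no step between measured compounds bears on this change, and the data give no basis for a direction. The expectation for the step from compound 2 to compound 3 is therefore a change of about a 1.1-fold lower number from compound 2 to compound 3 (0.05 log units; within the scatter) in this assay, not beyond the scatter. On that basis compound 3 is estimated at 40000 nM in this assay, with a range from 15000 nM to 120000 nM.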

Compound 3, half-maximal inhibitory concentration: 60600 nM
The estimate for compound 3 lay 1.5-fold (0.18 log units) below the measured number; the measured number falls inside the stated range.
By their numbers in this assay, from the lowest: compounds 2, 1 and 3 (each within the scatter of the next).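

In this assay, replacing hydroxy(phenyl)methyl with 1-hydroxy-1-methylpentyl on a saturated chain carbon bound to a carbonyl carbon gives a 1.4-fold higher number from compound 2 to compound 3 (0.13 log units; within the scatter), so at this place the six-membered aromatic ring can give way to an open chain with no step beyond the scatter. Putting (2-hydroxy-2-methylhexyl)carbonyl in place of 2-methoxypropyl on an oxygen on a saturated carbon gives a 1.1-fold higher number from compound 1 to compound 3 (0.05 log units; within the scatter), which also lies within the scatter, so compounds 1, 2 and 3 show no readable order in this assay and these changes to the side chain show no measurable effect. Nothing in hand explains why these different side chains give values that cannot be told apart.

It remains open whether any group at this place can produce a step beyond the scatter, for example an amine or a carboxylic acid on the side chain, since all three groups shown carry no net charge. As far as these compounds go, the shared core is the same in all three compounds, so the contribution of its parts to these values also remains open.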